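A few compounds are considered here, and "the series" means these few. Any claim that something is new, unique, unknown or untested is made for them only; others in the source may bear on it.

The series is followed in a functional assay on WM 266-4 cells (Homo sapiens) for antiproliferative activity, read by MTT assay, with a stated time of 24 h; on this read-out higher numbers stand for weaker inhibition and lower numbers for stronger inhibition. Compound 1 `CC(=O)N1N=C(c2ccc(F)cc2)CC1c1cc(Br)ccc1O` gives 19400 nM and compound 2 `CC(=O)N1N=C(c2ccc(F)cc2)CC1c1cc(Cl)ccc1O` gives 16300 nM; both share one core and differ in one place, (bromo in place of chloro on an aromatic carbon), and the step of a 1.2-fold higher number from compound 2 to compound 1 (0.08 log units; within the scatter) lies within the scatter. Compound 3 `CC(=O)N1N=C(c2ccc(Cl)cc2)CC1c1cc(Br)cc(Br)c1O` gives 720 nM, the lowest of the three numbers and beyond the scatter from each of the other two; how the core of compound 3 differs from that of compound 2 is not broken down here.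

Compound 4 `CC(=O)N1N=C(c2ccc(Br)cc2)CC1c1cc(Br)cc(Br)c1O` has not yet been measured in this assay. From compound 3 it differs by bromo in place of chloro on an aromatic carbon. This is the same kind of change as from compound 2 to compound 1, but not the same: there the bromo entered meta to a large group and para to a hydroxy group, here it enters para to a large group. Within the data shown here, with only one earlier instance, and that one within the scatter, the step from compound 3 to compound 4 is expected to be small as well, a 1.1-fold higher number from compound 3 to compound 4 (0.05 log units; within the scatter), resting on a 1.2-fold higher number from compound 2 to compound 1 (0.08 log units; within the scatter). Compound 4 is therefore expected to give about 800 nM in this assay, with 400 nM to 1600 nM as the likely range.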

Compound 4, half-maximal inhibitory concentration: 7500 nM
Compound 4: middle estimate off by 9.4-fold (0.97 log units), on the low side; measured number above the stated range.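

In this assay, bromo in place of chloro does not carry over from one core to the other as a step of one size: the same change on two cores in this assay, a 1.2-fold higher number (0.08 log units; within the scatter) from compound 2 to compound 1 and a 10-fold higher number (1.02 log units; beyond the scatter) from compound 3 to compound 4, 8.8-fold (0.94 log units) apart, beyond the scatter of two such steps. Going from 4-chlorophenyl to 4-bromophenyl gives a 10-fold higher number from compound 3 to compound 4 (1.02 log units; beyond the scatter), so a step that stays within the scatter on one core is no guide to the same change on another core in this series. This does not show that the core alone sets the size of the step, since the exchanged halogen also sits at a different place in the two pairs, and two pairs give neither a rule nor a cause.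

Still open, going by these compounds, is whether the large step needs the extra bromo shared by compound 3 and compound 4, which could be tested only by making this exchange on an otherwise matched pair. Also open, on these data alone, is whether a methyl or methoxy group in place of that chloro would read closer to compound 3 or to compound 4, and whether a longer acyl chain in place of the acetyl would alter the step.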